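Replacing methoxy with piperidin-4-yl on the shared core

A few compounds are considered here, and "the series" means these few. Any claim that something is new, unique, unknown or untested is made for them only; others in the source may bear on it.

Measured in a functional assay on cells (Homo sapiens), read by thymidine incorporation; on this read-out lower numbers stand for stronger inhibition and higher numbers for weaker inhibition:
- compound 1 `CCc1cc(NCc2cccnc2)n2ncc(Br)c2n1`: 520 nM
- compound 2 `CC(O)c1cc(NCc2cccnc2)n2ncc(Br)c2n1`: 1400 nM
- compound 3 `COc1cc(NCc2cccnc2)n2ncc(Br)c2n1`: 2000 nM

Compound 3 stands apart from only one of the other two compounds. The measured change is a 3.8-fold higher number from compound 1 to compound 3 (0.59 log units; beyond the scatter), which lies beyond the scatter. By contrast, the change of a 1.4-fold higher number from compound 2 to compound 3 (0.15 log units; within the scatter) lies within it. The next compound, compound 4 `Brc1cnn2c(NCc3cccnc3)cc(C3CCNCC3)nc12`, has piperidin-4-yl in place of methoxy on an aromatic carbon.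

Going by the values given here, no measured compound carries a ring at this place, so the measured steps give only indirect guidance. The closest is the ethyl and methoxy pair, with the modest change of a 3.8-fold higher number from compound 1 to compound 3 (0.59 log units; beyond the scatter). This favours ethyl over methoxy. Against it stands compound 2, whose 1-hydroxyethyl group gives a 2.7-fold higher number from compound 1 to compound 2 (0.43 log units; beyond the scatter) relative to ethyl and leaves it level with methoxy. A carbon-linked group therefore does not guarantee a gain in this assay. The expected step is a 2.5-fold lower number from compound 3 to compound 4 (0.40 log units; beyond the scatter), a modest move towards a lower number, and it is uncertain. For compound 4 the estimated value is 800 nM, with an expected range from 150 nM to 3500 nM.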

Compound 4, half-maximal inhibitory concentration: 160 nM
Compound 4: the middle estimate sits 5.0-fold (0.70 log units) above what was measured; the measured number falls inside the stated range.
By their numbers in this assay, from the lowest: compound 4; then compound 1; then compounds 2 and 3 (each within the scatter of the next).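

At this aromatic carbon, next to the ring nitrogen, a ring group gave the lowest number of the series: in this assay piperidin-4-yl produces a 13-fold lower number from compound 3 to compound 4 (1.10 log units; beyond the scatter) and an 8.8-fold lower number from compound 2 to compound 4 (0.94 log units; beyond the scatter) and also a 3.3-fold lower number from compound 1 to compound 4 (0.51 log units; beyond the scatter) in the same direction. Among the earlier compounds ethyl held the lowest number, so these steps show that this place accepts a much larger group than ethyl, methoxy or 1-hydroxyethyl and that the series can move well past ethyl with a six-membered non-aromatic ring carrying a hetero atom. The data shown offer no measurement that would explain this gain.

The compounds shown leave open whether the ring itself or its nitrogen accounts for the change, as piperidin-4-yl brings both at once and no compound here has one without the other. As far as these compounds go, a cyclohexyl group, an open-chain amine such as 4-aminobutyl, or a piperidin-4-yl group with a methyl on its nitrogen would pull these apart, and how far the ring can grow at this place also remains unknown.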